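Cytotoxicity of a pyrazolotriazine series: fluorophenyl to hydroxyethyl

The compounds below may be only part of what the source reports. "The series", "measured", "known", "first", "only" and "open" are said of these compounds alone.

Compound 1 `Nc1nn2c(O)cc(CCl)nc2c1[N+](=O)[O-]` and compound 2 `Nc1nn2c(O)cc(CNNc3ccc(F)cc3)nc2c1[N+](=O)[O-]` share a core and were both examined in an ADME assay (Homo sapiens) for cytotoxicity; a higher number here means that more compound is tolerated, a lower number that less compound is tolerated. Compound 1 reaches only a limit there, giving > 50 ug/mL. Compound 2 likewise yields only a limit, > 100 ug/mL. Neither figure is a number, as both rest on the stated limits, the limit of > 100 ug/mL in this assay, at which 1 of the 2 values shown sits, and (the limit of > 50 ug/mL in this assay, at which 1 of the 2 values shown sits). Compound 2 therefore stands at the upper edge of what this assay reports, alongside compound 1. Compound 3 `Nc1nn2c(O)cc(CNNCCO)nc2c1[N+](=O)[O-]` remains to be measured; it differs from compound 2 by 2-hydroxyethyl in place of 4-fluorophenyl on an amine nitrogen. Going by the values given here, no step between measured compounds is available; given that compound 2 sits at the limit of > 100 ug/mL in this assay, at which 1 of the 2 values shown sits, no change beyond the scatter is expected in this assay. Compound 3 is therefore expected to give 100 ug/mL, within 50 ug/mL to 200 ug/mL, most likely again as a limit. The expected step is a number no higher from compound 2 to compound 3 (the limit leaves the size open), none beyond the usual scatter.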

Compound 3, half-maximal cytotoxic concentration: > 50 ug/mL
Compound 3: only a limit was reported; the forecaster's own chance of this, stated with the estimate: 80%; the middle value is on the limit's open side.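

Compound 3, like compound 1 and compound 2, gives only a limit in this assay, so no step can be read from compound 2 or compound 1 to compound 3. Going by these compounds, whether 2-hydroxyethyl in place of 4-fluorophenyl changes the tolerated concentration at all stays open.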